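Swapping thiophen-2-yl for 2-bromo-4-fluorophenyl on the shared core

This account rests on a few compounds, and the source may have more. Where it says the series, first, only, none or still open, it means among the compounds named here.

Values measured so far in a functional assay on HCT-116 cells (Homo sapiens) for antiproliferative activity, read by MTT assay (a higher number here means a weaker inhibitor, a lower number a stronger inhibitor), are these:
- Compound 1 `Cc1cccc(/C=N/Nc2ncc3c(n2)n(C2CCCC2)c(=O)c(=O)n3C)c1` gives > 100000 nM as a limit and not a number.
- Compound 2 `Cn1c(=O)c(=O)n(C2CCCC2)c2nc(N/N=C/c3cccc(Cl)c3Cl)ncc21` gives 26400 nM as a number.
- Compound 3 `Cn1c(=O)c(=O)n(C2CCCC2)c2nc(N/N=C/c3cccs3)ncc21` gives 52600 nM as a number.

For the measured compounds named here, compound 2 at 26400 nM and compound 3 at 52600 nM lie within the scatter of each other and are the only two true numbers in the set. Compound 4 `Cn1c(=O)c(=O)n(C2CCCC2)c2nc(N/N=C/c3ccc(F)cc3Br)ncc21` differs from compound 3 by a single change 2-bromo-4-fluorophenyl in place of thiophen-2-yl on a carbon with a double bond to nitrogen with 2-bromo-4-fluorophenyl in place of thiophen-2-yl on a carbon with a double bond to nitrogen.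

Going by the values given here, the closest guide is compound 2, the only measured compound with a halogen-bearing phenyl, and a 2.0-fold higher number from compound 2 to compound 3 (0.30 log units; within the scatter) is a step that stays within the scatter. The steps of an at least 3.7-fold lower number from compound 1 to compound 2 (0.57 log units; beyond the scatter) and an at least 1.9-fold lower number from compound 1 to compound 3 (0.27 log units; that floor lies within the scatter) start from the limit of > 100000 nM in this assay, at which 1 of the 3 values shown sits, and so give floors only. The first lies beyond the scatter, while the floor of the second lies within it. In this assay a small move toward a lower number is therefore expected, and nothing beyond the scatter. The estimated change is a 1.8-fold lower number from compound 3 to compound 4 (0.24 log units; within the scatter) and no more than that. For compound 4 the estimate is 30000 nM with an expected range from 10000 nM to 90000 nM at this stage.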

Compound 4, half-maximal inhibitory concentration: 8390 nM
For compound 4 the middle estimate is 3.6-fold (0.55 log units) above the measured one; the measured number lies below the stated range.
By their numbers in this assay, from the lowest: compound 4; then compounds 2 and 3 (each within the scatter of the next). At a limit, above all of these: compound 1.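

In this assay, the group on a carbon with a double bond to nitrogen now produces a difference beyond the scatter between two true numbers, something compounds 2 and 3 did not show: the step is a 6.3-fold lower number from compound 3 to compound 4 (0.80 log units; beyond the scatter), with 2-bromo-4-fluorophenyl entering and thiophen-2-yl leaving. The choice among halogen-bearing phenyl groups also counts at this position, as 2-bromo-4-fluorophenyl in place of 2,3-dichlorophenyl gives a 3.1-fold lower number from compound 2 to compound 4 (0.50 log units; beyond the scatter), so the presence of halogen on the phenyl ring does not by itself set the value. The widest step, an at least 11-fold lower number from compound 1 to compound 4 (1.07 log units; beyond the scatter), is a floor only and not a full measure of the change, since its starting value is a limit and not a number: the limit of > 100000 nM in this assay, at which 1 of the 4 values shown sits.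

Every group shown at this position is an aromatic ring, so the effect of an amine, a carboxylic acid or a longer chain there remains open. Also open, as far as these compounds go, is what the bromine and the fluorine each contribute alone, and whether the same ranking would hold with any other part of the shared core changed.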